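A few compounds are considered here, and "the series" means these few. Any claim that something is new, unique, unknown or untested is made for them only; others in the source may bear on it.

Measured so far:
- Compound 1 `Nc1cc2c(-n3nc(-c4ccccn4)nc3N)ncnc2cc1Cl`: 3000 nM
- Compound 2 `COc1cc2ncnc(-n3nc(-c4cccnc4)nc3N)c2cc1OC`: 27000 nM
- Compound 3 `COc1cc2ncnc(-n3nc(-c4ccccn4)nc3N)c2cc1OCCCNC(=O)CN1C[C@@H](C)O[C@@H](C)C1`: 34000 nM

In a physicochemical assay for solubility, in phosphate buffer, with a stated time of 18 h, at pH 7.4 (a lower number here means a less soluble compound, a higher number a more soluble compound), compound 3 gives 34000 nM. That number lies within the scatter of compound 2 at 27000 nM, and stands well clear of compound 1 at 3000 nM, a gap beyond the scatter.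

Compound 4 `COc1cc2ncnc(-n3nc(-c4ccccn4)nc3N)c2cc1OCCCNC(=O)OCC(F)(F)F` has not yet been measured. It departs from compound 3 in one place: 2,2,2-trifluoroethoxy in place of (2,6-dimethylmorpholin-4-yl)methyl on a carbonyl carbon. In words, 2,2,2-trifluoroethoxy stands in place of (2,6-dimethylmorpholin-4-yl)methyl on a carbonyl carbon.

Among the compounds with values here, no two measured compounds differ in one place, so this change has no direct precedent. The three values give only a rough frame, with compound 1 at 3000 nM marking how low a member of this set has gone. A fall beyond the scatter is expected, though with little certainty, and the estimated step is a 5.7-fold lower number from compound 3 to compound 4 (0.75 log units; beyond the scatter). For compound 4 the expected value is 6000 nM, with an estimated range of 1500 nM to 25000 nM.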

Compound 4, solubility: 100 nM
Estimate against measurement, compound 4: 60-fold (1.78 log units) above; measured number outside the range, below it.
By their numbers in this assay, from the lowest: compound 4; then compound 1; then compounds 2 and 3 (each within the scatter of the next).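

In this assay, putting 2,2,2-trifluoroethoxy in place of (2,6-dimethylmorpholin-4-yl)methyl on a carbonyl carbon gives a 340-fold lower number from compound 3 to compound 4 (2.53 log units; beyond the scatter), a large step. Within the data shown here, it is the first change in this set that can be read in one place, and it shows that the group on this carbonyl carbon can, by itself, move the number far while the shared core stays the same. The change takes away a six-membered non-aromatic ring with 2 hetero atoms and 2 defined stereocentres and brings in a group with no ring, but this single pair cannot separate those differences.

Nothing shown here bears on the cause of the step. Going by these compounds, it remains open whether a plain morpholine, a primary amine or a carboxylic acid on this carbonyl carbon would keep the number close to that of compound 3.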